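Lengthening an amide chain on a macrolide core

The source may report more compounds than this note shows. Statements on the series, on what has been measured and on what is new or still open speak of the compounds shown alone.

Compounds measured in a physicochemical assay for lipophilicity, read by HPLC, measured as chromatographic lipophilicity, at pH 7.4; on this read-out higher numbers stand for higher lipophilicity and lower numbers for lower lipophilicity:
compound 1, `CC[C@H]1OC(=O)[C@H](C)[C@@H](O[C@H]2C[C@@](C)(OC)[C@@H](O)[C@H](C)O2)[C@H](C)[C@@H](O[C@@H]2O[C@H](C)C[C@H](N(C)C)[C@H]2O)[C@](C)(O)C[C@@H](C)CN(C)[C@H](C)[C@@H](OCCCNC(=O)c2c(C)nn(C)c2Cl)[C@]1(C)O`, gives 3.01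
compound 2, `CC[C@H]1OC(=O)[C@H](C)[C@@H](O[C@H]2C[C@@](C)(OC)[C@@H](OCCCNC(=O)COC)[C@H](C)O2)[C@H](C)[C@@H](O[C@@H]2O[C@H](C)C[C@H](N(C)C)[C@H]2O)[C@](C)(O)C[C@@H](C)CN(C)[C@H](C)[C@@H](O)[C@]1(C)O`, gives 2.16
compound 3, `CC[C@H]1OC(=O)[C@H](C)[C@@H](O[C@H]2C[C@@](C)(OC)[C@@H](O)[C@H](C)O2)[C@H](C)[C@@H](O[C@@H]2O[C@H](C)C[C@H](N(C)C)[C@H]2O)[C@](C)(O)C[C@@H](C)CN(C)[C@H](C)[C@@H](OCCCNC(C)=O)[C@]1(C)O`, gives 2.41

Among these three, compound 3 stands second highest in this assay; it sits close to compound 2, within the scatter, while compound 1 lies beyond the scatter above it. Among the compounds with values here, the step from compound 1 to compound 3, a number 0.60 log units lower from compound 1 to compound 3 (beyond the scatter), is the only single-point comparison measured.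

Compound 4, `CCCCCCCC(=O)NCCCO[C@@H]1[C@@H](C)N(C)C[C@H](C)C[C@@](C)(O)[C@H](O[C@@H]2O[C@H](C)C[C@H](N(C)C)[C@H]2O)[C@@H](C)[C@H](O[C@H]2C[C@@](C)(OC)[C@@H](O)[C@H](C)O2)[C@@H](C)C(=O)O[C@H](CC)[C@@]1(C)O`, differs from compound 3 by hexyl in place of hydrogen on a saturated chain carbon bound to a carbonyl carbon. Within the data shown here, no measured step adds a plain saturated chain, so the direction and size rest on general experience: six added carbons are expected to raise this assay clearly beyond the scatter. For compound 4 the estimate is 5, spanning 4.2 to 5.8, which means an expected step of a number 2.59 log units higher from compound 3 to compound 4 (beyond the scatter).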

Compound 4, distribution coefficient: 5.18
Estimate against measurement, compound 4: 0.18 log units below; measured number inside the range.
By their numbers in this assay, from the lowest: compounds 2 and 3 (each within the scatter of the next); then compound 1; then compound 4.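

In this assay, within the data shown here, hexyl in place of hydrogen on a saturated chain carbon bound to a carbonyl carbon gives a number 2.77 log units higher from compound 3 to compound 4 (beyond the scatter) and is the only measured step here that adds a plain saturated chain. Exchanging the group on the carbonyl carbon for a plain chain gives a number 2.17 log units higher from compound 1 to compound 4 (beyond the scatter) and so puts the plain chain above the group that held the highest number before. Nothing measured here explains these steps.

The compounds shown leave open where a butyl chain would fall and whether a longer chain would raise the number further. As far as these compounds go, how an amine or a carboxylic acid at the chain end would read also remains open.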